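Swapping Ethoxy for Bromo on the Shared Core

The source may report more compounds than this note shows. Statements on the series, on what has been measured and on what is new or still open speak of the compounds shown alone.

Compound 1 `CCOc1ccc2oc(/C=C/[S+](C)[O-])cc(=O)c2c1` gives 1500 nM in a functional assay on A549 cells (Homo sapiens) for cytotoxicity, with a stated time of 48 h; a higher number here means a weaker inhibitor, a lower number a stronger inhibitor.
Compound 2 `CC(C)C(=O)Oc1ccc2oc(/C=C/[S+](C)[O-])cc(=O)c2c1` gives 2400 nM in this assay.

Both measured compounds share one core and differ only in the group attached to an oxygen on the aromatic ring. Compound 1 has the lowest of the two numbers; its nearest neighbour is compound 2, and the step of a 1.6-fold higher number from compound 1 to compound 2 (0.20 log units; within the scatter) stays within the scatter, so the two cannot be ranked.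

Compound 3 `C[S+]([O-])/C=C/c1cc(=O)c2cc(Br)ccc2o1` has not yet been measured. It differs from compound 1 as follows: bromo in place of ethoxy on an aromatic carbon. Among the measured compounds shown here, the one measured step keeps the oxygen in place and only alters what hangs on it, so nothing measured here speaks directly to removing the oxygen altogether and putting a halogen in its place. Without a bearing step, the expectation for compound 3 leans on the near-identity of the two measured compounds and is given a wide range. The number for compound 3 is expected to be close to that of compound 1, with the estimated step of a 1.3-fold higher number from compound 1 to compound 3 (0.12 log units; within the scatter) lying within the scatter. Compound 3 is therefore estimated at 2000 nM, between 700 nM and 6000 nM.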

Compound 3, half-maximal inhibitory concentration: 1100 nM
Compound 3: the middle estimate sits 1.8-fold (0.26 log units) above what was measured, within the range that was stated.
By their numbers in this assay, from the lowest: compounds 3, 1 and 2 (each within the scatter of the next, the first and the last beyond it).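

The oxygen on this aromatic carbon turns out not to be needed to keep a number of this size in this assay: bromo in place of ethoxy removes that oxygen and the hydrogen-bond acceptor it carries, and replaces 3 heavy atoms with 1, yet gives a 1.4-fold lower number from compound 1 to compound 3 (0.13 log units; within the scatter), so these two compounds cannot be ranked. Set against the (isopropylcarbonyl)oxy group, the same position gives a 2.2-fold lower number from compound 2 to compound 3 (0.34 log units; beyond the scatter), a modest step but the only one among the three compounds that lies beyond the scatter. Nothing available here explains why groups this different give numbers so close together.

The compounds shown leave open whether a different kind of group on this carbon, such as an amine, a carboxylic acid or a longer alkoxy chain, would move the number further in either direction. They also leave open whether another halogen, such as chloro or fluoro, would behave like bromo, and whether a hydrogen at this position would give a similar number.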